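Amide methylation and microsomal clearance in the series

The source may hold more compounds than are shown below. What is called first, only, known or untested is meant among the compounds shown, and "the series" means these compounds.

Measured so far:
- compound 1 `C[C@H](Nc1ncnc(N)c1C#N)c1nc2ccc(F)cc2c(-c2ccccn2)c1-c1ccccn1`: 16 mL.min-1.g-1
- compound 2 `C[C@H](Nc1ncnc(N)c1C#N)c1nc2ccc(F)cc2c(C(N)=O)c1-c1ccccc1`: < 14 mL.min-1.g-1

In an ADME assay on microsomes from liver (Rattus norvegicus) for pharmacokinetics, using NADPH, with a stated time of 30 min, tested at 1 uM (a lower number here means slower removal, a higher number faster removal of the compound), compound 1 gives 16 mL.min-1.g-1. For compound 2 the reading in this assay is a limit, not a number, so compound 2 sits at the limit of < 14 mL.min-1.g-1 in this assay, at which 1 of the 2 values shown sits. Compound 3 `CNC(=O)c1c(-c2ccccc2)c([C@H](C)Nc2ncnc(N)c2C#N)nc2ccc(F)cc12` is not yet measured; it differs from compound 2 by methyl in place of hydrogen on an amide-type nitrogen. Within the data shown here, no step between measured compounds exists to anchor this change, so the step from compound 2 to compound 3 is expected to be small, an at least 1.1-fold higher number from compound 2 to compound 3 (0.05 log units; that floor lies within the scatter), possibly a slight rise but likely within the scatter. Compound 3 is therefore expected at 16 mL.min-1.g-1. Compound 3 is estimated to fall between 7 mL.min-1.g-1 and 35 mL.min-1.g-1 in this assay.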

Compound 3, intrinsic clearance in microsomes: 15 mL.min-1.g-1
Beside the measured number, compound 3's estimate is 1.1-fold (0.03 log units) above it; the measured number falls inside the stated range.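

In this assay, methyl in place of hydrogen on the amide-type nitrogen gives an at least 1.0-fold higher number from compound 2 to compound 3 (0.02 log units; that floor lies within the scatter), the first step readable at this position. Compound 2 has only a limit, not a number: the limit of < 14 mL.min-1.g-1 in this assay, at which 1 of the 3 values shown sits. The step is therefore a floor, and a larger rise in clearance is not excluded.

Open, as far as these compounds go, is the true size of the change from carbamoyl to methylcarbamoyl. Also open, from the compounds shown here alone, is whether a longer chain on this nitrogen, such as ethyl or propyl, would move the number beyond the scatter.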